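This account rests on a few compounds, and the source may have more. Where it says the series, first, only, none or still open, it means among the compounds named here.

Working notes on the chloromethylbenzyl series.

Compound 1 `ClCc1ccc(Cn2cnc3c(Cl)ncnc32)cc1` gives 2040 nM in a functional assay on HCC 2998 cells (Homo sapiens) for cytotoxicity, read by sulforhodamine B assay, with a stated time of 48 h; on this read-out lower numbers stand for stronger inhibition of growth and higher numbers for weaker inhibition of growth. Compound 2 `Nc1nc(Cl)c2ncn(Cc3ccc(CCl)cc3)c2n1` gives 8910 nM in this assay. The change amino in place of hydrogen on an aromatic carbon produced a 4.4-fold higher number from compound 1 to compound 2 (0.64 log units; beyond the scatter). Compound 3 `ClCc1ccccc1Cn1cnc2c(Cl)ncnc21` gives 3540 nM in this assay; its core and the core of compound 1 hold the same atoms joined differently, and that difference is not broken down here. Compound 4 `Nc1nc(Cl)c2ncn(Cc3ccccc3CCl)c2n1` carries the change (amino in place of hydrogen on an aromatic carbon); the surroundings of the place read the same as for compound 2, so this is the same change. Among the compounds with values here, the step of a 4.0-fold higher number from compound 3 to compound 4 (0.60 log units; beyond the scatter) is expected from compound 3 to compound 4 in this assay, resting on the single earlier instance a 4.4-fold higher number from compound 1 to compound 2 (0.64 log units; beyond the scatter) and on the single pairing available. Compound 4 is therefore expected near 14000 nM, with the likely range running from 6000 nM to 35000 nM.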

Compound 4, concentration for total growth inhibition: 6610 nM
For compound 4 the middle estimate is 2.1-fold (0.33 log units) above the measured one; measured number inside the range.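

Amino in place of hydrogen on an aromatic carbon gives a 1.9-fold higher number from compound 3 to compound 4 (0.27 log units; within the scatter) in this assay. Set beside the earlier step, the result does not separate the two cores: the same change on two cores in this assay, a 4.4-fold higher number (0.64 log units; beyond the scatter) from compound 1 to compound 2 and a 1.9-fold higher number (0.27 log units; within the scatter) from compound 3 to compound 4, 2.3-fold (0.37 log units) apart, within the scatter of two such steps. The two steps are therefore compatible with one shared effect of the change across these cores, but two pairs in one assay do not establish a constant step size, and they show nothing about carrying the change to any further core.

Open, on these data alone, is whether a methylamino group or a hydroxyl group at the same place would read like amino. Also open, as far as these compounds go, is how either pair would read with a bromomethyl group in place of the chloromethyl group.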